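The source may hold more compounds than are shown below. What is called first, only, known or untested is meant among the compounds shown, and "the series" means these compounds.

Measured compounds and their values in an ADME assay on the whole organism (strain Zucker) for pharmacokinetics, with Rattus norvegicus as the target, with stated times of 24 h and 14 days, at a dose of 3 mg/kg by the oral route; a higher number here means more compound in the circulation at the dose given, a lower number less compound in the circulation:
- compound 1, `Cn1c(COc2cccc(C(=O)O)c2)nc2ccc(Oc3ccc4c(c3)CCC4)nc21`, gives 4080 ng.h/mL
- compound 2, `Cn1c(COc2cccc(C(=O)O)c2)nc2ccc(Oc3ccc4c(c3)OCC4)nc21`, gives 3390 ng.h/mL
- compound 3, `Cn1c(COc2cccc(C(=O)O)c2)nc2ccc(Oc3ccc(Cl)cn3)cc21`, gives 1010 ng.h/mL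

Compound 3 stands lowest of the three in this assay; compound 2 is nearest to it and compound 1 furthest, and both gaps lie beyond the scatter. Compound 4, `Cc1cnc(Oc2ccc3nc(COc4cccc(C(=O)O)c4)n(C)c3c2)c(F)c1`, differs from compound 3 by 3-fluoro-5-methylpyridin-2-yl in place of 5-chloropyridin-2-yl on an oxygen on an aromatic ring. Among the measured compounds shown here, only one measured step bears on such a change: the swap of one bicyclic group for another on the aryloxy oxygen, a 1.2-fold lower number from compound 1 to compound 2 (0.08 log units; within the scatter), which stayed within the scatter. That step concerns a different pair of groups and a different core, so it is a weak guide, but it is all there is. On that basis an exchange of one six-membered aromatic group for another at the same kind of place is expected to give no step beyond the scatter, a 1.1-fold higher number from compound 3 to compound 4 (0.04 log units; within the scatter). Compound 4 is therefore estimated at 1100 ng.h/mL, with a range from 400 ng.h/mL to 3000 ng.h/mL.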

Compound 4, area under the concentration-time curve in the Rattus norvegicus assay: 3610 ng.h/mL
Compound 4: middle estimate off by 3.3-fold (0.52 log units), on the low side; measured number outside the range, above it.
By their numbers in the Rattus norvegicus assay, from the lowest: compound 3; then compounds 2, 4 and 1 (each within the scatter of the next).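

Among the compounds shown here, in the Rattus norvegicus assay, compound 3 gives 1010 ng.h/mL and compound 4 gives 3610 ng.h/mL; 3-fluoro-5-methylpyridin-2-yl in place of 5-chloropyridin-2-yl on an oxygen on an aromatic ring gives a 3.6-fold higher number from compound 3 to compound 4 (0.55 log units; beyond the scatter), so an exchange between two groups with one six-membered aromatic ring each can move this number beyond the scatter at this place, which the only earlier step, a 1.2-fold lower number from compound 1 to compound 2 (0.08 log units; within the scatter), did not show. In a physicochemical assay for solubility, read by HPLC, measured as thermodynamic solubility, with a stated time of 4 h, at pH 6.8 (on this read-out lower numbers stand for lower solubility and higher numbers for higher solubility), compound 3 gives 17 ug/mL and compound 4 gives 9.2 ug/mL; the same exchange stays within the scatter, with a 1.8-fold lower number from compound 3 to compound 4 (0.27 log units; within the scatter), so the step in the circulation is not matched by a step beyond the scatter in solubility. No measurement at hand accounts for the step.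

Chlorine leaves while fluorine and a methyl enter together, so the compounds shown do not separate what each contributes. They also leave open how a pyridin-2-yl group carrying an amine or a nitrile would stand on the same oxygen.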